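The compounds below may be only part of what the source reports. "The series", "measured", "known", "first", "only" and "open" are said of these compounds alone.

Compound 1 `CC(C)CSc1nc(N)nc2c1ncn2/C=C1/CC1(CO)CO`: > 20000 nM
Compound 2 `CCOc1nc(N)nc2c1ncn2/C=C1/CC1(CO)CO`: > 20000 nM
Compound 3 `Nc1nc(OCc2ccccc2)c2ncn(/C=C3/CC3(CO)CO)c2n1`: > 20000 nM

The three values above come from an ADME assay on BCBL1 cells (Homo sapiens) for cytotoxicity, with a stated time of 7 days; a higher number here means that more compound is tolerated, a lower number that less compound is tolerated. Compound 1 reaches only the limit > 20000 nM, which is a limit of the measurement and not a number. Compound 3 likewise stops at the limit > 20000 nM. Compound 2 stands at the limit > 20000 nM, so its true position is known only as lying beyond that point. The steps among these compounds are a step that the two limits leave unreadable from compound 1 to compound 2, a step that the two limits leave unreadable from compound 1 to compound 3 and a step that the two limits leave unreadable from compound 2 to compound 3; none has a readable size because of the limit of > 20000 nM in this assay, at which 3 of the 3 values shown sit.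

Compound 4 `CC(C)Nc1nc(N)nc2c1ncn2/C=C1/CC1(CO)CO` differs from compound 2 by isopropylamino in place of ethoxy on an aromatic carbon. The measured steps bear on this change only by showing that three different groups at this position all leave the compound at the limit in this assay. Among the measured compounds shown here, no step gives a size or a direction to build on. Compound 4 is therefore expected to sit at 20000 nM, with a range from 10000 nM to 40000 nM. The expected step of a number no higher from compound 2 to compound 4 (the limit leaves the size open) is estimated to be none beyond the scatter, most likely with the result again reported only as a limit.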

Compound 4, half-maximal cytotoxic concentration: > 20000 nM
Compound 4: only a limit was reported; the forecaster's own chance of this, stated with the estimate: 85%; the middle value sits exactly at the limit.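

No step from compound 4 to compound 1, compound 2 or compound 3 can be read, because each of these values is a limit and not a number: the limit of > 20000 nM in this assay, at which 4 of the 4 values shown sit.

The compounds shown leave open how much compound each tolerates in this assay, and whether changing the group on the aromatic carbon makes any difference there.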